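Swapping the Pyrazole on an Amide Nitrogen

The source may hold more compounds than are shown below. What is called first, only, known or untested is meant among the compounds shown, and "the series" means these compounds.

Measured compounds:
compound 1, `Cc1ccc(OCC(=O)N(Cc2cccs2)c2ccnn2C)cc1`: 422 nM
compound 2, `Cc1ccc2oc(C(=O)N(Cc3cccs3)c3ccn[nH]3)cc2c1`: 40 nM

Both compounds were tested in an assay on HEK293 cells for agonist activity at transient receptor potential cation channel subfamily M member 8 (Homo sapiens), read by fluorescence and calcium flux, with a stated time of 15 min; on this read-out higher numbers stand for an effect only at larger amounts of compound and lower numbers for an effect already at smaller amounts. Compound 1 gives 422 nM, the higher of the two numbers. Compound 2 gives 40 nM, a lower number, and the gap between the two lies beyond the usual scatter. Compound 2 differs from compound 1 in more than one place, so its lower number cannot be traced to any single change.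

Compound 3, `Cc1ccc(OCC(=O)N(Cc2cccs2)c2cn[nH]c2)cc1`, has not been measured. It differs from compound 1 in one place: 1H-pyrazol-4-yl in place of 1-methyl-1H-pyrazol-5-yl on an amide-type nitrogen. Within the data shown here, no measured pair shows a change of this kind, so the direction of the step is open. The step from compound 1 to compound 3 in this assay is expected to be small, a 1.1-fold lower number from compound 1 to compound 3 (0.02 log units; within the scatter), not clearly beyond the scatter. Compound 3 is therefore estimated at 400 nM, with a range from 120 nM to 1500 nM.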

Compound 3, half-maximal effective concentration: 1.4 nM
For compound 3 the middle estimate is 290-fold (2.46 log units) above the measured one, and the stated range ends above it.
By their numbers in this assay, from the lowest: compound 3; then compound 2; then compound 1.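

This position on the amide-type nitrogen proves highly sensitive: in this assay, placing 1H-pyrazol-4-yl where 1-methyl-1H-pyrazol-5-yl stood gives a 300-fold lower number from compound 1 to compound 3 (2.48 log units; beyond the scatter), even though both groups are five-membered aromatic rings with 2 hetero atoms. Among these compounds, as the only pair here that differs in one place, it ties a large shift in the number to this single spot on the shared core. No measurement shown here explains the size of this step.

On these data alone, the change combines two differences, the loss of the methyl group and a new point of attachment on the pyrazole, so their shares remain open; a 1-methyl-1H-pyrazol-4-yl group on the same nitrogen would help separate them. Also open, as far as these compounds go, is whether a phenyl ring at this position would give a similarly low number.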